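The source may hold more compounds than are shown below. What is called first, only, known or untested is meant among the compounds shown, and "the series" means these compounds.

Three compounds of the series have numbers in an assay on cells for antagonist activity at transient receptor potential cation channel subfamily V member 1 (Homo sapiens), read by FLIPR and calcium flux, with a stated time of 6 min; a higher number here means a weaker inhibitor, a lower number a stronger inhibitor. Compound 1 `CCCN(CCC)c1nc(C(C)(C)C)ccc1CNC(=O)C(C)c1ccc(NS(C)(=O)=O)c(F)c1` gives 2.5 nM; compound 2 `CCCCCCOc1nc(C(C)(C)C)ccc1CNC(=O)C(C)c1ccc(NS(C)(=O)=O)c(F)c1` gives 2.7 nM; compound 3 `CC(C)CCOc1nc(C(C)(C)C)ccc1CNC(=O)C(C)c1ccc(NS(C)(=O)=O)c(F)c1` gives 0.8 nM. Compound 3 stands lowest of the three: the step of a 3.1-fold lower number from compound 1 to compound 3 (0.49 log units; beyond the scatter) and the step of a 3.4-fold lower number from compound 2 to compound 3 (0.53 log units; beyond the scatter) both lie beyond the scatter, while the step of a 1.1-fold higher number from compound 1 to compound 2 (0.03 log units; within the scatter) lies within it. Compound 4 `CCCCCSc1nc(C(C)(C)C)ccc1CNC(=O)C(C)c1ccc(NS(C)(=O)=O)c(F)c1` is not yet measured. It differs from compound 3 in one place: pentylsulfanyl in place of isopentyloxy on an aromatic carbon. Going by the values given here, no measured step exchanges an oxygen for a sulfur, so the only bearing comes from the step of a 3.4-fold lower number from compound 2 to compound 3 (0.53 log units; beyond the scatter), in which isopentyloxy in place of hexyloxy gave a modestly lower number; compound 4 carries pentylsulfanyl, a chain of the same kind as the hexyloxy of compound 2 rather than the isopentyloxy of compound 3. On that basis a modest rise back toward the numbers of compound 1 and compound 2 is expected, with the sulfur an open question. The expected step is a 2.0-fold higher number from compound 3 to compound 4 (0.30 log units; within the scatter). For compound 4 the number in this assay is estimated at 1.6 nM, with a range from 0.5 nM to 5 nM.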

Compound 4, inhibition constant: 3.1 nM
The estimate for compound 4 lay 1.9-fold (0.29 log units) below the measured number, within the range that was stated.
By their numbers in this assay, from the lowest: compound 3; then compounds 1, 2 and 4 (each within the scatter of the next).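

In this assay, pentylsulfanyl in place of isopentyloxy on the aromatic carbon next to the ring nitrogen gives a 3.9-fold higher number from compound 3 to compound 4 (0.59 log units; beyond the scatter). Pentylsulfanyl in place of hexyloxy gives a 1.1-fold higher number from compound 2 to compound 4 (0.06 log units; within the scatter), and in place of dipropylamino it gives a 1.2-fold higher number from compound 1 to compound 4 (0.09 log units; within the scatter), so sulfur-, oxygen- and nitrogen-linked groups all occur among the three compounds that stay within the scatter of one another, and compound 3 alone stands apart. No supporting data bear on the reason for this gap.

The shown compounds leave open whether the separation of compound 3 follows the branched chain, the oxygen link, or only their combination. An isopentylsulfanyl group or an isopentylamino group at this position would separate those two features.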